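The compounds below may be only part of what the source reports. "The series", "measured", "known", "first", "only" and "open" are said of these compounds alone.

Measured compounds:
- compound 1, `CCCOC(=O)Nc1ccc([Se]C#N)cc1`, in a functional assay on PC-3 cells (Homo sapiens) for cytotoxicity, read by MTT assay, with a stated time of 72 h (a lower number here means a stronger inhibitor of growth, a higher number a weaker inhibitor of growth), gives 47400 nM
- compound 2, `CC(C)COC(=O)Nc1ccc([Se]C#N)cc1`, in this assay gives 47300 nM

Compound 2 stands with the lowest of the two numbers, but its nearest neighbour is compound 1, and the step of a 1.0-fold lower number from compound 1 to compound 2 (0.00 log units; within the scatter) lies within the scatter, so the two values show no separation. Compound 3, `C=CCOC(=O)Nc1ccc([Se]C#N)cc1`, is not yet measured. It differs from compound 2 by vinyl in place of isopropyl on a saturated chain carbon bound to an oxygen next to a carbonyl group; read one bond further out, isobutyl gives way to allyl, or isobutoxy to allyloxy.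

Among the measured compounds shown here, only one measured step bears on this change, the one from compound 1 to compound 2, which also alters the chain on the carbamate oxygen and gave a 1.0-fold lower number from compound 1 to compound 2 (0.00 log units; within the scatter). That step was flat, and the move to compound 3 again keeps the shared core and the carbamate while reshaping only the small alkyl chain. Compound 3 is therefore expected to show a step of a 1.1-fold lower number from compound 2 to compound 3 (0.02 log units; within the scatter) in this assay, that is, nothing beyond the scatter. The estimate for compound 3 in this assay is 45000 nM, with a range from 20000 nM to 100000 nM.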

Compound 3, concentration for total growth inhibition: 44700 nM
The estimate for compound 3 lay 1.0-fold (0.00 log units) above the measured number; the range from low to high includes it.
By their numbers in this assay, from the lowest: compounds 3, 2 and 1 (each within the scatter of the next).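

In this assay, vinyl in place of isopropyl on a saturated chain carbon bound to an oxygen next to a carbonyl group gives (a 1.1-fold lower number from compound 2 to compound 3 (0.02 log units; within the scatter)), and vinyl in place of ethyl at the same place gives (a 1.1-fold lower number from compound 1 to compound 3 (0.03 log units; within the scatter)). Where the earlier pair carried only saturated chains at this place, compound 3 brings a double bond outside aromatic rings into the chain, turning isobutoxy into allyloxy, and neither step leaves the scatter, so all three compounds read alike across these small chains. Nothing shown here offers an explanation for this sameness.

The compounds shown carry only small hydrocarbon chains on the carbamate oxygen, so they leave open what a longer chain, a benzyl group or a chain ending in an amine would do at this place in this assay. They also leave open whether the numbers would stay alike if the shared core or the carbamate itself were altered, since all three compounds keep both unchanged.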